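The source may hold more compounds than are shown below. What is called first, only, known or untested is meant among the compounds shown, and "the series" means these compounds.

Two compounds of this series carry a measurement in a functional assay on MGC-803 cells (Homo sapiens) for cytotoxicity, read by MTT assay, with a stated time of 72 h; a lower number here means a stronger inhibitor, a higher number a weaker inhibitor. Compound 1, `CCCCCCNc1nc(SCc2ccc(C(F)(F)F)cc2)nc2ccccc12`, gives 13100 nM. Compound 2, `FC(F)(F)c1ccc(CSc2nc(Nc3cccc(C(F)(F)F)c3)c3ccccc3n2)cc1`, gives 15100 nM. Of the two numbers in hand, compound 2 carries the higher one, but the step of a 1.2-fold higher number from compound 1 to compound 2 (0.06 log units; within the scatter) lies within the scatter, so the two values cannot be told apart. Compound 3, `Cc1ccc(Nc2nc(SCc3ccc(C(F)(F)F)cc3)nc3ccccc23)cc1`, awaits measurement in this assay. It differs from compound 2 in one place: 4-methylphenyl in place of 3-(trifluoromethyl)phenyl on a nitrogen on an aromatic ring. Among the measured compounds shown here, the only measured step at this nitrogen, a 1.2-fold higher number from compound 1 to compound 2 (0.06 log units; within the scatter), exchanged hexyl for 3-(trifluoromethyl)phenyl and moved the number by less than the scatter. For the measured compounds named here, compound 3 keeps an aromatic ring on that nitrogen and alters only what sits on it; no measured pair shows what such an exchange does. With nothing pointing either way, the step expected in this assay is a 1.1-fold lower number from compound 2 to compound 3 (0.03 log units; within the scatter), that is, nothing beyond the scatter. The estimate for compound 3 in this assay is 14000 nM, within a range from 6000 nM to 33000 nM.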

Compound 3, half-maximal inhibitory concentration: 36100 nM
Compound 3: middle estimate off by 2.6-fold (0.41 log units), on the low side, and the stated range ends below it.
By their numbers in this assay, from the lowest: compounds 1 and 2 (each within the scatter of the next); then compound 3.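

In this assay, among the compounds shown here, the group on this nitrogen can move the number: the exchange of 3-(trifluoromethyl)phenyl for 4-methylphenyl gives a 2.4-fold higher number from compound 2 to compound 3 (0.38 log units; beyond the scatter) and is the first step beyond the scatter, whereas the earlier exchange of hexyl for 3-(trifluoromethyl)phenyl could not be told from repeat variation. The exchange of hexyl for 4-methylphenyl gives a 2.8-fold higher number from compound 1 to compound 3 (0.44 log units; beyond the scatter) so carrying an aromatic ring on the nitrogen does not by itself fix the outcome: compound 2 stays within the scatter of compound 1 while compound 3, also an aryl amine, does not. No measurement bears on why the 4-methylphenyl compound stands apart.

The exchange from 3-(trifluoromethyl)phenyl to 4-methylphenyl alters both the group on the ring and its place on it, so the compounds shown cannot separate the two changes. From the compounds shown here alone, whether a 3-methylphenyl or 4-(trifluoromethyl)phenyl would side with compound 2 or with compound 3 stays open, as does whether a carboxylic acid on that ring or a chain longer than hexyl on the nitrogen would take the number lower than the values of compound 1 and compound 2.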